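The compounds below may be only part of what the source reports. "The series", "measured", "known", "first", "only" and "open" are said of these compounds alone.

Measured compounds:
compound 1, `C=CC1=C(C(=O)NCc2ccccc2)C(c2ccc(OC)cc2)OC1`, > 100000 nM
compound 2, `C=CC1=C(C(=O)NC(C)(C)C)C(c2ccc(OC)cc2)OC1`, > 100000 nM
compound 3, `C=CC1=C(C(=O)Nc2ccc(OCC)cc2)C(c2ccc(OC)cc2)OC1`, > 100000 nM

These three compounds share one core and differ only in the group carried on the amide-type nitrogen. In a functional assay on HeLa cells (Homo sapiens) for cytotoxicity, read by MTT assay, with a stated time of 24 h (a higher number here means a weaker inhibitor, a lower number a stronger inhibitor), compound 1 is reported as a limit of the assay, > 100000 nM, not as a number. Compound 2 likewise gives a limit, > 100000 nM. Compound 3 also gives a limit, > 100000 nM. The measured steps are therefore a step that the two limits leave unreadable from compound 1 to compound 2, a step that the two limits leave unreadable from compound 1 to compound 3 and a step that the two limits leave unreadable from compound 2 to compound 3; all three rest on (the limit of > 100000 nM in this assay, at which 3 of the 3 values shown sit). Compound 2 thus stands at that limit, with nothing to set it apart from the other two.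

Compound 4, `C=CC1=C(C(=O)NC(C)(C)C)C(c2ccc(F)cc2)OC1`, differs from compound 2 by fluoro in place of methoxy on an aromatic carbon. For the measured compounds named here, none of the measured steps touches this ring; they all concern the amide-type nitrogen, and none yields a readable size. No basis exists for expecting a change beyond the scatter in this assay, so compound 4 is expected to remain near the limit. The estimate for compound 4 is 150000 nM, with a range from 40000 nM to 600000 nM. The expected step is a step that the limit leaves unreadable from compound 2 to compound 4.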

Compound 4, half-maximal inhibitory concentration: > 100000 nM
Compound 4: only a limit was reported; the forecaster's own chance of this, stated with the estimate: 85%; the middle value lies beyond the limit too.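

Compound 2 and compound 4 both give only a limit in this assay, not a number, so no step between them can be read: the limit of > 100000 nM in this assay, at which 4 of the 4 values shown sit.

The compounds shown leave open whether any group on the amide-type nitrogen or the aromatic ring would give a readable number in this assay.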